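The source may report more compounds than this note shows. Statements on the series, on what has been measured and on what is new or still open speak of the compounds shown alone.

Within the data shown here, compound 3 `COc1cc2nccc(Oc3ccc(NC(=O)c4nnc(-c5ccc(F)cc5)o4)cc3)c2cc1OC` gives 5140 nM in a functional assay on A549 cells (Homo sapiens) for antiproliferative activity, read by MTT assay, with a stated time of 72 h (on this read-out higher numbers stand for weaker inhibition and lower numbers for stronger inhibition), the second highest of the three numbers so far: compound 2 `COc1cc2nccc(Oc3ccc(NC(=O)c4ncc(-c5ccc(F)cc5)o4)cc3)c2cc1OC` gives 5590 nM and compound 1 `COc1cc2c(Oc3ccc(NC(=O)c4cc(-c5ccc(F)cc5)on4)cc3)ccnc2cc1OCCCN1CCC(C)CC1` gives 3340 nM, and both lie within the scatter of compound 3. Compound 4 `COc1cc2nccc(Oc3ccc(NC(=O)c4cc(-c5ccc(F)cc5)on4)cc3)c2cc1OC` differs from compound 3 at a single point: 5-(4-fluorophenyl)-1,2-oxazol-3-yl in place of 5-(4-fluorophenyl)-1,3,4-oxadiazol-2-yl on a carbonyl carbon. Among the measured compounds shown here, only one measured step touches this five-membered ring, a 1.1-fold lower number from compound 2 to compound 3 (0.04 log units; within the scatter), and it shows how little such a swap moved the read-out. Compound 1, which carries the same 5-(4-fluorophenyl)-1,2-oxazol-3-yl group but differs elsewhere from compound 3, also sits within the scatter of compound 3. The expected step in this assay is therefore none beyond the scatter, a 1.2-fold lower number from compound 3 to compound 4 (0.09 log units; within the scatter). Compound 4 is thus estimated at 4200 nM, within the range 1500 nM to 12000 nM.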

Compound 4, half-maximal inhibitory concentration: 40400 nM
Beside the measured number, compound 4's estimate is 9.6-fold (0.98 log units) below it; the whole stated range lies below it.
By their numbers in this assay, from the lowest: compounds 1, 3 and 2 (each within the scatter of the next); then compound 4.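

In this assay the five-membered ring on the carbonyl carbon does matter: moving to 5-(4-fluorophenyl)-1,2-oxazol-3-yl brings a 7.9-fold higher number from compound 3 to compound 4 (0.90 log units; beyond the scatter) and a 7.2-fold higher number from compound 2 to compound 4 (0.86 log units; beyond the scatter), although the two groups it replaces had matched each other. The 2-(4-methylpiperidin-1-yl)ethyl group also counts with this ring in place, since hydrogen in its stead brings a 12-fold higher number from compound 1 to compound 4 (1.08 log units; beyond the scatter). Nothing measured here explains either change. Still open, on these data alone, is whether a morpholine in place of the 4-methylpiperidine, or a shorter chain, would keep the number of compound 1.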